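The compounds below may be only part of what the source reports. "The series", "measured", "known", "first", "only" and "open" are said of these compounds alone.

Measured in a functional assay on SK-OV-3 cells (Homo sapiens) for cytotoxicity, read by spectrophotometry, with a stated time of 72 h; on this read-out lower numbers stand for stronger inhibition and higher numbers for weaker inhibition:
- compound 1 `COc1ccc(-n2c(-c3cc(OC)c(OC)c(OC)c3)cccc2=O)cc1`: 1540 nM
- compound 2 `COc1cc(-c2cccc(=O)n2-c2ccc([N+](=O)[O-])cc2)cc(OC)c1OC`: 311 nM
- compound 3 `COc1cc(-c2cccc(=O)n2-c2cccc(F)c2)cc(OC)c1OC`: 340 nM

Compound 3 stands level with compound 2, as a 1.1-fold higher number from compound 2 to compound 3 (0.04 log units; within the scatter) shows, and well clear of compound 1, as a 4.5-fold lower number from compound 1 to compound 3 (0.66 log units; beyond the scatter) shows. The next analogue is compound 4 `COc1cc(-c2cccc(=O)n2-c2ccncc2)cc(OC)c1OC`, with pyridin-4-yl in place of 3-fluorophenyl on an aromatic nitrogen. Swaps of the group at this nitrogen have so far given a 5.0-fold lower number from compound 1 to compound 2 (0.69 log units; beyond the scatter), alongside the two steps above. For the measured compounds named here, none of the measured compounds has a hetero atom in this ring, so direction is poorly defined. In this assay, a modest rise at most is expected. The expected change is a 1.5-fold higher number from compound 3 to compound 4 (0.18 log units; within the scatter). For compound 4 the estimated value is 520 nM, with an expected range of 140 nM to 2000 nM.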

Compound 4, half-maximal inhibitory concentration: 3020 nM
The estimate for compound 4 lay 5.8-fold (0.76 log units) below the measured number, outside the stated range (above it).
By their numbers in this assay, from the lowest: compounds 2 and 3 (each within the scatter of the next); then compounds 1 and 4 (each within the scatter of the next).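

In this assay, for the compounds shown here, a ring hetero atom at this nitrogen costs potency for the first time: pyridin-4-yl gives an 8.9-fold higher number from compound 3 to compound 4 (0.95 log units; beyond the scatter) and a 9.7-fold higher number from compound 2 to compound 4 (0.99 log units; beyond the scatter). Against the 4-methoxyphenyl analogue the step stays within the scatter, at a 2.0-fold higher number from compound 1 to compound 4 (0.29 log units; within the scatter), so compound 4 stands level with compound 1 and well clear of compound 2 and compound 3. No measurement at hand explains this result.

Going by these compounds, whether the loss follows the ring nitrogen itself or its place in the ring stays open. A pyridin-3-yl group, or a phenyl ring carrying an amine, would help separate these readings.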